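The source may hold more compounds than are shown below. What is called first, only, known or untested is meant among the compounds shown, and "the series" means these compounds.

Measured compounds:
- compound 1, `CCCCN/C(=C1/N=CN(CCOC)C1=O)c1cc2ccccc2[nH]1`: 75.4%
- compound 2, `COCCN1C=N/C(=C(/NCCN(C)C)c2cc3ccccc3[nH]2)C1=O`: 64.6%

In an assay on isolated protein for inhibition of Calpain-1 catalytic subunit (Homo sapiens), read by fluorescence, with a stated time of 60 min, tested at 1 uM (a higher number here means more inhibition at the concentration tested (going by the name of the read-out), a lower number less inhibition), compound 1 gives 75.4%, while compound 2 gives 64.6%. Among the compounds with values here, compound 2 thus holds the lower of the two numbers seen so far; the only measured step bearing on it is a number 10.8 percentage points lower from compound 1 to compound 2 (beyond the scatter).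

Compound 3, `COCCCN/C(=C1/N=CN(CCOC)C1=O)c1cc2ccccc2[nH]1`, has not yet been measured. It differs from compound 2 in one place: methoxymethyl in place of dimethylamino on a saturated chain carbon, two bonds along the chain from an amine nitrogen. Read one bond further out, the chain that ends in a (2-(dimethylamino)ethyl)amino group in compound 2 becomes a (3-methoxypropyl)amino group in compound 3, so the chain length is close to the butyl chain of compound 1 but carries an oxygen rather than a nitrogen.

Within the data shown here, only one measured step is at hand, and it moved in the opposite direction: inserting dimethylamino cost a number 10.8 percentage points lower from compound 1 to compound 2 (beyond the scatter). Removing that dimethylamino again in favour of methoxymethyl is therefore expected to recover part of that loss, giving a modest upward step, a number 7.4 percentage points higher from compound 2 to compound 3 (within the scatter), in this assay. Compound 3 is estimated at 72%, with a range from 58% to 84%.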

Compound 3, a percentage reported as inhibition, at one concentration (the size of the read-out at that concentration, not a potency): 71.8%
Estimate against measurement, compound 3: 0.2 percentage points above, and the stated range covers the measured number.
By their numbers in this assay, from the lowest: compounds 2, 3 and 1 (each within the scatter of the next, the first and the last beyond it).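

In this assay, the step from dimethylamino to methoxymethyl on this chain is a number 7.2 percentage points higher from compound 2 to compound 3 (within the scatter), and the step from methyl to methoxy on the chain end is a number 3.6 percentage points lower from compound 1 to compound 3 (within the scatter). Neither step clears the usual scatter, so the (3-methoxypropyl)amino chain of compound 3 cannot be told apart from either neighbour, even though the step of a number 10.8 percentage points lower from compound 1 to compound 2 (beyond the scatter) does clear it. What the new compound adds is therefore a limit on interpretation: an oxygen in this chain is compatible with a reading close to that of the all-carbon chain, but these numbers cannot place it on one side or the other of the gap, and no measurement here explains that gap.

The three compounds leave open whether the number in this assay would be higher, lower or level with other chain ends, such as a hydroxyl group, a carboxylic acid or a longer chain. They also leave open whether these close readings at a single concentration would stay close if full potencies were measured.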